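From a methoxymethyl amide to a bromopropenyl amide

The source may hold more compounds than are shown below. What is called first, only, known or untested is meant among the compounds shown, and "the series" means these compounds.

Compound 1 `COCC(=O)N(Cc1ccc(OC)c(O)c1)c1cc(OC)c(OC)c(OC)c1` was tested in a functional assay on MGC-803 cells (Homo sapiens) for inhibition, read by MTT assay, with a stated time of 48 h (a higher number here means a weaker inhibitor, a lower number a stronger inhibitor), and gives 79 nM. Compound 2 `COC(=O)c1cc(CNc2cc(OC)c(OC)c(OC)c2)ccc1OC` gives 49600 nM in this assay, so compound 1 stands at the lowest of the two numbers, and its gap to compound 2 lies far beyond the usual scatter. Compound 3 `COc1ccc(CN(C(=O)/C=C/CBr)c2cc(OC)c(OC)c(OC)c2)cc1O` has not yet been measured. It differs from compound 1 in one place: 3-bromoprop-1-en-1-yl in place of methoxymethyl on a carbonyl carbon. Going by the values given here, no pair of measured compounds isolates a change of this kind, so the expectation for compound 3 rests on compound 1 alone, with the amide kept and only the group on its carbonyl carbon exchanged. A step of a 1.4-fold lower number from compound 1 to compound 3 (0.16 log units; within the scatter) is expected, that is, a modest gain at most and possibly nothing beyond the scatter. Compound 3 is estimated to give 55 nM in this assay, with a range from 15 nM to 250 nM.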

Compound 3, half-maximal inhibitory concentration: 71 nM
For compound 3 the middle estimate is 1.3-fold (0.11 log units) below the measured one; the measured number falls inside the stated range.
By their numbers in this assay, from the lowest: compounds 3 and 1 (each within the scatter of the next); then compound 2.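

In this assay, placing 3-bromoprop-1-en-1-yl instead of methoxymethyl on the carbonyl carbon gives a 1.1-fold lower number from compound 1 to compound 3 (0.05 log units; within the scatter), so this exchange leaves the read-out indistinguishable from that of compound 1. The hydrogen-bond acceptor counted in methoxymethyl leaves and a bromine and a double bond enter, yet the two compounds stay within the scatter of each other, which shows that this position can carry more than one kind of group at this level of activity. Nothing available explains why these two groups read alike.

On these data alone, the bromine and the double bond enter together, so their separate contributions remain open, and a plain prop-1-en-1-yl group would pull them apart. As far as these compounds go, it also remains open how far this tolerance extends, for example to an amine, a carboxylic acid or a longer chain on the same carbonyl carbon.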